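Flipping One Ring Stereocentre: What to Expect

The source may hold more compounds than are shown below. What is called first, only, known or untested is meant among the compounds shown, and "the series" means these compounds.

Compound 1 `O=C(N1CCCC[C@@H]1COCc1ccccc1)n1cc(-c2ccc(-c3ccccc3)cc2)nn1` gives 3.16 nM in an assay on HEK293 cells for inhibition of Monoacylglycerol lipase ABHD6 (Homo sapiens), read by fluorescence; a lower number here means a stronger inhibitor, a higher number a weaker inhibitor. Among the measured compounds shown here, compound 2 `O=C(N1CC=C[C@@H](O)[C@@H]1COCc1ccccc1)n1cc(-c2ccc(-c3ccccc3)cc2)nn1` gives 794 nM in this assay, the highest of the two numbers so far, and its gap to compound 1 lies well beyond the scatter. Compound 3 `O=C(N1CC=C[C@@H](O)[C@H]1COCc1ccccc1)n1cc(-c2ccc(-c3ccccc3)cc2)nn1` shares every atom and bond with compound 2 and differs at a single point: the two compounds have the same atoms and bonds and differ only in configuration as drawn: 1 of 2 stereo elements differ; a stereocentre at a saturated ring carbon is drawn S in compound 2 and R in compound 3. For the measured compounds named here, no measured pair shows what such a flip does here, so the direction is open, and a step beyond the scatter either way is possible. Compound 3 is expected at 250 nM, within 25 nM to 2500 nM. The estimated step is a 3.2-fold lower number from compound 2 to compound 3 (0.50 log units; beyond the scatter).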

Compound 3, half-maximal inhibitory concentration: 251 nM
Compound 3: middle estimate off by 1.0-fold (0.00 log units), on the low side; measured number inside the range.
By their numbers in this assay, from the lowest: compound 1; then compound 3; then compound 2.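

Among the compounds shown here, this is the first direct reading of what the configuration at this saturated ring carbon is worth: in this assay, going from S to R gives a 3.2-fold lower number from compound 2 to compound 3 (0.50 log units; beyond the scatter). The step is modest but beyond the scatter, so the drawn configuration at this position matters for ABHD6 inhibition. The step can be assigned to this stereocentre alone because of one fact: the fact that compounds 2 and 3 differ only in the configuration as drawn

The compounds shown leave open what flipping the other stereocentre alone would do. They also leave open whether this flip would give a similar step with an amine in place of the hydroxyl.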